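Taking the hydroxy group off a very weak inhibitor

The compounds below may be only part of what the source reports. "The series", "measured", "known", "first", "only" and "open" are said of these compounds alone.

Values in a functional assay for inhibition, with Homo sapiens as the target; on this read-out higher numbers stand for weaker inhibition and lower numbers for stronger inhibition:
Compound 1 `Cc1cc2c(cc1C(=O)N=C(N)N)S(=O)(=O)CCC2C`: 655 nM
Compound 2 `Cc1cc2c(cc1C(=O)N=C(N)N)S(=O)(=O)C(C)(C)C2(C)O`: 102 nM
Compound 3 `N=C(N)NC(=O)c1ccc2c(c1)S(=O)(=O)CC2O`: > 100000 nM (a limit of the assay, not a number)

Two of these compounds return real numbers: compound 1 reads 655 nM and compound 2 reads 102 nM. Compound 3 sits at the limit of > 100000 nM in this assay, at which 1 of the 3 values shown sits. Its true value is therefore unknown, and it offers only a floor to start from.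

Compound 4 `N=C(N)NC(=O)c1ccc2c(c1)S(=O)(=O)CC2` differs from compound 3 in one place: hydrogen in place of hydroxy on a saturated ring carbon. In short, it has hydrogen in place of hydroxy on a saturated ring carbon. For the measured compounds named here, no measured pair here shows what this swap does in this assay, so the size of the step has to be judged with little support. Compound 3, at > 100000 nM, gives a limit as the only starting point. A small move toward stronger inhibition is the expectation, and compound 4 may well stay at the limit and return no number. The expected change is an at least 2.5-fold lower number from compound 3 to compound 4 (0.39 log units; beyond the scatter). Compound 4 is estimated at 40000 nM, with an expected range of 5000 nM to 100000 nM.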

Compound 4, half-maximal inhibitory concentration: > 100000 nM
Compound 4: no number, only a limit (the forecaster's own chance of this, stated with the estimate: 45%); at least 2.5-fold (0.39 log units) between middle value and limit.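

In this assay compound 3 and compound 4 each give only a limit, not a number, so the step between them cannot be read: the limit of > 100000 nM in this assay, at which 2 of the 4 values shown sit.

From the compounds shown here alone, how strongly either compound really inhibits, and whether hydrogen in place of hydroxy on a saturated ring carbon changes that at all, stays open.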